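This account rests on a few compounds, and the source may have more. Where it says the series, first, only, none or still open, it means among the compounds named here.

Compounds measured so far:
- compound 1, `CC1(C)C=C(n2ccccc2=O)c2cc(S(N)(=O)=O)ccc2O1`, 92.1%
- compound 2, `CC1(C)C=C(n2ccccc2=O)c2cc(S(=O)(=O)Nc3ccc(C#N)cc3)ccc2O1`, 90.8%

Going by the values given here, in a functional assay on the whole organism (trachea) with Rattus norvegicus as the target (on this read-out lower numbers stand for smaller maximal responses and higher numbers for larger maximal responses), compound 2 stands lowest of the two numbers, with compound 1 nearest, and the only measured step, a number 1.3 percentage points lower from compound 1 to compound 2 (within the scatter), did not rise above the scatter. Compound 3, `CC1(C)C=C(n2ccccc2=O)c2cc(S(=O)(=O)c3ccccc3)ccc2O1`, has not yet been measured. It differs from compound 2 at the sulfonyl group: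

phenyl in place of (4-cyanophenyl)amino on a sulfonyl sulfur

Among the compounds with values here, the one step on record bears on this change only loosely: it also altered the sulfonyl substituent, and it left this assay essentially unchanged, as a number 1.3 percentage points lower from compound 1 to compound 2 (within the scatter) shows. Nothing in the two measured compounds points to a step beyond the scatter in either direction when phenyl takes the place of (4-cyanophenyl)amino on the sulfonyl sulfur. Compound 3 is therefore expected to give about 90% in this assay, within a range of 78% to 98%. The step this estimate implies, a number 0.8 percentage points lower from compound 2 to compound 3 (within the scatter), is expected to fall within the usual scatter, with the wider range reflecting that the change at the sulfonyl sulfur is not directly covered by the measured pair.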

Compound 3, largest response reached (Emax), in percent of the reference or control that the assay uses: 88.1%
The estimate for compound 3 lay 1.9 percentage points above the measured number; the measured number falls inside the stated range.
By their numbers in this assay, from the lowest: compounds 3, 2 and 1 (each within the scatter of the next).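

Going by these compounds alone, until now, the only change on record at the sulfonyl group had replaced a hydrogen on the sulfonamide nitrogen, so the nitrogen attached to the sulfonyl sulfur had always remained in place. Compound 3 removes that nitrogen and attaches phenyl directly to the sulfonyl sulfur, yet this assay shows a number 2.7 percentage points lower from compound 2 to compound 3 (within the scatter) when phenyl takes the place of (4-cyanophenyl)amino and a number 4 percentage points lower from compound 1 to compound 3 (within the scatter) when it takes the place of amino, so among these three compounds neither the nitrogen nor the nitrile is needed to keep the maximal response within the scatter, even though phenyl has 0 hydrogen-bond donors. No measurement available here explains this result.

As far as these compounds go, the three groups compared on the sulfonyl sulfur are amino, (4-cyanophenyl)amino and phenyl, so it remains open whether a small methyl group, a morpholine ring or a phenyl ring bearing a carboxylic acid would also stay within the scatter. From the compounds shown here alone, it is also open whether the same freedom holds elsewhere on the shared core, for example if the sulfonyl group gave way to a carboxylic acid or a nitrile.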